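Adding a Methyl Group to a Pyrazoline Series

A few compounds are considered here, and "the series" means these few. Any claim that something is new, unique, unknown or untested is made for them only; others in the source may bear on it.

The series rests on three measured compounds. Compound 1 `Cc1ccc(C2=NN(C3=NC(c4ccccc4)CS3)C(c3ccc4ccccc4c3)C2)cc1` is examined in a functional assay on BGC-823 cells (Homo sapiens) for inhibition, read by CCK-8 assay, with a stated time of 48 h (a higher number here means a weaker inhibitor, a lower number a stronger inhibitor), where compound 1 gives 8940 nM. Compound 3 `O=C1CSC(N2N=C(c3ccc(Br)cc3)CC2c2ccc3ccccc3c2)=N1` gives 11700 nM in this assay, and compound 2 `O=C1CSC(N2N=C(c3ccc(Cl)cc3)CC2c2cccc3ccccc23)=N1` gives 16400 nM. The three numbers sit close together: the value of compound 1 is not separated from that of compound 3 or that of compound 2 beyond the usual scatter, so none of the three can be set apart from the others on these data.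

Compound 4 `Cc1ccc(C2=NN(C3=NC(c4ccccc4)CS3)C(c3ccc4ccccc4c3)C2)cc1C` has not yet been measured. It differs from compound 1 by a single change, (methyl in place of hydrogen on an aromatic carbon), that is, methyl in place of hydrogen on an aromatic carbon, so that the 4-methylphenyl group of compound 1 becomes a 3,4-dimethylphenyl group. For the measured compounds named here, no measured pair in this set shows the effect of such an addition, so there is no step to lean on. Given how small the change is and how tightly the three measured values cluster, the step from compound 1 to compound 4 is expected to be a 1.1-fold lower number from compound 1 to compound 4 (0.05 log units; within the scatter), no further than the scatter in either direction. Compound 4 is therefore estimated at 8000 nM, within a range from 3500 nM to 20000 nM.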

Compound 4, half-maximal inhibitory concentration: 6570 nM
Compound 4: middle estimate off by 1.2-fold (0.09 log units), on the high side, within the range that was stated.
By their numbers in this assay, from the lowest: compounds 4, 1, 3 and 2 (each within the scatter of the next, the first and the last beyond it).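

For the compounds shown here, the step from the 4-methylphenyl group to the 3,4-dimethylphenyl group is the first single-place comparison, and it comes to a 1.4-fold lower number from compound 1 to compound 4 (0.13 log units; within the scatter) in this assay. Going by these compounds alone, it shows that this aromatic carbon, ortho to a methyl group and meta to a large group, can carry one more methyl group without compound 4 separating from compound 1 on this read-out, something the earlier compounds could not show because no two of them differed in one place only. Nothing available here accounts for the size of this step.

On these data alone, whether an amine, a carboxylic acid, a methoxy group or a longer chain such as propyl on this same aromatic carbon would carry the number beyond the scatter remains open, since a single methyl step sets no trend and gives no direction for larger or differently built groups. Also open, as far as these compounds go, is whether the same methyl addition would behave alike on the core of compound 2 or compound 3, which differ from compound 1 in more than one place and so offer no comparison with it.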